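Chlorine on the benzylsulfanyl phenyl ring of compound 1

The compounds below may be only part of what the source reports. "The series", "measured", "known", "first", "only" and "open" are said of these compounds alone.

Among the compounds with values here, compound 1 `C/C(C#Cc1ccccc1)=N\N/C(N)=N/S(=O)(=O)c1cc(C)c(Cl)cc1SCc1ccccc1` has the lower of the two numbers measured so far: in a functional assay on HCT-116 cells (Homo sapiens) for antiproliferative activity, read by MTT assay, with a stated time of 72 h (a higher number here means a weaker inhibitor, a lower number a stronger inhibitor), compound 1 gives 10000 nM, while compound 2 `Cc1cc(S(=O)(=O)/N=C(\N)N/N=C/C#Cc2ccccc2)c(SCc2ccccc2Cl)cc1Cl` gives 27000 nM in this assay, a gap beyond the scatter. Compound 3 `C/C(C#Cc1ccccc1)=N\N/C(N)=N/S(=O)(=O)c1cc(C)c(Cl)cc1SCc1ccc(Cl)cc1` differs from compound 1 in one place: chloro in place of hydrogen on an aromatic carbon. Within the data shown here, no step of this kind has yet been measured, so the size of the change is expected to be small, within the scatter, with no clear direction. Compound 3 is therefore estimated at 12000 nM in this assay, between 5000 nM and 35000 nM, a step of a 1.2-fold higher number from compound 1 to compound 3 (0.08 log units; within the scatter).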

Compound 3, half-maximal inhibitory concentration: 10000 nM
Compound 3: the middle estimate sits 1.2-fold (0.08 log units) above what was measured, and the stated range covers the measured number.
By their numbers in this assay, from the lowest: compounds 1 and 3 (each within the scatter of the next); then compound 2.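

In this assay, within the data shown here, chloro in place of hydrogen on the benzylsulfanyl phenyl ring gives no change at the digits printed from compound 1 to compound 3 (within the scatter), the first one-place step. The position therefore takes a chloro para to a large group with the antiproliferative reading held, at least on the core of compound 1. No measurement at hand bears on the reason for this result.

From the compounds shown here alone, whether an amine or a carboxylic acid at this place would give the same reading remains open. A single step also leaves open whether the same holds on other cores.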